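The compounds below may be only part of what the source reports. "The series", "measured", "known", "first", "only" and "open" are said of these compounds alone.

In an ADME assay on HEK293 cells (Homo sapiens) for cytotoxicity, read by MTT assay, with a stated time of 24 h (a higher number here means a weaker inhibitor, a lower number a stronger inhibitor), compound 2 `CN(C)CCCNc1nc2cc([N+](=O)[O-])ccc2nc1NCc1ccc(Cl)cc1` gives 10.7 ug/mL and sits within the scatter of compound 1 `CN(C)CCCCNc1nc2cc([N+](=O)[O-])ccc2nc1NCc1ccc(C(F)(F)F)cc1` at 9.73 ug/mL while compound 3 `CN(C)CCCNc1nc2cc([N+](=O)[O-])ccc2nc1NCc1ccccc1Br` stands clearly higher at 51.9 ug/mL in this series. Compound 4 `CN(C)CCCNc1nc2cc([N+](=O)[O-])ccc2nc1NCc1cccc(C(F)(F)F)c1` carries 3-(trifluoromethyl)phenyl in place of 4-chlorophenyl on a saturated chain carbon bound to a nitrogen on an aromatic ring. Going by the values given here, only one measured step bears directly on this change: a 4.9-fold higher number from compound 2 to compound 3 (0.69 log units; beyond the scatter) for another swap at the same place, modest in size. Compound 1 also holds a trifluoromethyl group and lies close to compound 2 in value, but the two differ in more than one place. A small upward step is therefore expected, an estimated 1.4-fold higher number from compound 2 to compound 4 (0.15 log units; within the scatter) that stays inside the scatter. In this assay compound 4 is estimated at 15 ug/mL with 6 ug/mL to 40 ug/mL as the expected range.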

Compound 4, half-maximal inhibitory concentration: 7.99 ug/mL
Estimate against measurement, compound 4: 1.9-fold (0.27 log units) above; measured number inside the range.
By their numbers in this assay, from the lowest: compounds 4, 1 and 2 (each within the scatter of the next); then compound 3.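

In this assay, 3-(trifluoromethyl)phenyl on a saturated chain carbon bound to a nitrogen on an aromatic ring gives a 1.3-fold lower number from compound 2 to compound 4 (0.13 log units; within the scatter) against 4-chlorophenyl, so this swap leaves the number unchanged within the scatter. Against 2-bromophenyl, the same group gives a 6.5-fold lower number from compound 3 to compound 4 (0.81 log units; beyond the scatter) and thus a clear separation. Among these three groups at this place, only 2-bromophenyl stands apart so far, and no data here explain that.

Going by these compounds, how a phenyl carrying a nitrile or a carboxylic acid would read at this place remains open. So does whether a longer chain would alter these readings.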